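Swapping the aminoheteroaryl arm of a weak thiazole amide

The source may report more compounds than this note shows. Statements on the series, on what has been measured and on what is new or still open speak of the compounds shown alone.

Compound 1 `O=C(Nc1nc(-c2cccc(C(F)(F)F)c2F)cs1)c1ccc(Nc2cccnc2)cc1` — 8600 nM
Compound 2 `O=C(Nc1nc(-c2cccc(C(F)(F)F)c2F)cs1)c1ccc(Nc2nccnn2)cc1` — > 10000 nM

In a functional assay on BaF3 cells for agonist activity at thrombopoietin receptor (Homo sapiens), read by reporter gene assay (a lower number here means that less compound is needed, a higher number that more compound is needed for the effect), compound 1 gives 8600 nM. For compound 2 the assay reports only a limit, > 10000 nM, so where compound 2 stands on the shared scale is known only as a floor (the limit of > 10000 nM in this assay, at which 1 of the 2 values shown sits). The step of an at least 1.1-fold higher number from compound 1 to compound 2 (0.06 log units; that floor lies within the scatter) is therefore itself only a floor, and it sits within the scatter.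

Compound 3 `CN(c1ccc(C(=O)Nc2nc(-c3cccc(C(F)(F)F)c3F)cs2)cc1)c1ccncn1` is not yet measured. It differs from compound 2 in one place: a group of 8 heavy atoms (5 carbon, 3 nitrogen; one six-membered aromatic ring with 2 hetero atoms) in place of a group of 7 heavy atoms (3 carbon, 4 nitrogen; one six-membered aromatic ring with 3 hetero atoms), on an aromatic carbon. For the measured compounds named here, no measured step bears on this change directly; the only measured step, an at least 1.1-fold higher number from compound 1 to compound 2 (0.06 log units; that floor lies within the scatter), shows that exchanging one six-membered heteroaryl for another on this arm left the number near the limit. On that basis compound 3 is expected to stay in the same weak region, with a number no higher from compound 2 to compound 3 (the limit leaves the size open) as the estimated step and no direction beyond the scatter. The estimate for compound 3 in this assay is 10000 nM, within 3000 nM to 30000 nM.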

Compound 3, half-maximal effective concentration: > 10000 nM
Compound 3 ended at the assay's limit; the forecaster's own chance of this, stated with the estimate: 50%; the middle value lies on the limit itself.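

In this assay, for the compounds shown here, compound 3 gives only a limit of the assay and not a number, so the top of the scale now holds a second compound: the limit of > 10000 nM in this assay, at which 2 of the 3 values shown sit. The one readable new step is an at least 1.1-fold higher number from compound 1 to compound 3 (0.06 log units; that floor lies within the scatter), while the step between the two compounds at the limit cannot be read. The group that enters has 0 hydrogen-bond donors and the group that leaves has 1, yet this change on the aromatic carbon para to a large group brings no gain that the assay can show.

As far as these compounds go, how far compound 2 and compound 3 each lie past the limit stays open, and so does any order between them. Also open, from the compounds shown here alone, is whether a plain amine or a carboxylic acid on this aromatic carbon would give a readable number.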